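Swapping the aryl group on the piperazine of compound 2

A few compounds are considered here, and "the series" means these few. Any claim that something is new, unique, unknown or untested is made for them only; others in the source may bear on it.

Among the measured compounds shown here, of the two compounds measured so far, compound 2 `COc1ccccc1N1CCN(CCCCCC(=O)N2Cc3ccccc3C[C@H]2C(N)=O)CC1` gives the highest number in an assay on HEK293 cells for displacement of a labelled ligand from 5-hydroxytryptamine receptor 7 (Homo sapiens), with a stated time of 1 h (a lower number here means a stronger inhibitor, a higher number a weaker inhibitor), at 302 nM, and its nearest neighbour, compound 1 `NC(=O)[C@@H]1CCCN1C(=O)CCCCCCN1CCN(c2noc3ccccc23)CC1`, gives 101 nM, a difference that lies beyond the usual scatter. Compound 3 `NC(=O)[C@@H]1Cc2ccccc2CN1C(=O)CCCCCN1CCN(c2cccc(Cl)c2Cl)CC1` has not yet been measured; it differs from compound 2 in one place: 2,3-dichlorophenyl in place of 2-methoxyphenyl on an amine nitrogen in a ring. For the measured compounds named here, no measured pair shows this exchange, so the size of the step is uncertain. A modest weakening is expected, with an estimated step of a 1.7-fold higher number from compound 2 to compound 3 (0.22 log units; within the scatter). Compound 3 is therefore expected to reach about 500 nM, within a range from 150 nM to 1500 nM.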

Compound 3, inhibition constant: 95 nM
The estimate for compound 3 lay 5.3-fold (0.72 log units) above the measured number, and the stated range ends above it.
By their numbers in this assay, from the lowest: compounds 3 and 1 (each within the scatter of the next); then compound 2.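

In this assay, 2,3-dichlorophenyl in place of 2-methoxyphenyl on the ring amine nitrogen gives a 3.2-fold lower number from compound 2 to compound 3 (0.50 log units; beyond the scatter) and so strengthens binding. This shows that the aryl group at this position matters to the result, and that this exchange, which removes the hydrogen-bond acceptor of the leaving group, costs nothing here. Nothing on hand explains the gain. Going by these compounds, whether a single chlorine or an unsubstituted phenyl would hold the gain remains open. So does whether the same exchange would carry over to a longer chain.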